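Compound 4: does clearance return without the carbonyl?

This account rests on a few compounds, and the source may have more. Where it says the series, first, only, none or still open, it means among the compounds named here.

In an ADME assay on microsomes from liver (Homo sapiens) for metabolic stability, read by LC-MS, using NADPH, with stated times of 5 min and 30 min, tested at 1 uM (on this read-out higher numbers stand for fast clearance and lower numbers for slow clearance), three compounds have been measured:
- compound 1 `COCCC(=O)Nc1cnc(NCc2c(F)ccc3c2CCO3)n2cnnc12` gives < 3 mL.min-1.g-1 as a limit of the assay
- compound 2 `CN(c1ccccc1)c1cnc(NCc2c(F)ccc3c2CCO3)n2cnnc12` gives 55 mL.min-1.g-1 as a number
- compound 3 `O=C(Nc1cnc(NCc2c(F)ccc3c2CCO3)n2cnnc12)c1cccnc1` gives < 3 mL.min-1.g-1 as a limit of the assay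

Compound 3 stands at the limit of < 3 mL.min-1.g-1 in this assay, at which 2 of the 3 values shown sit, and so has a limit, not a number. Compound 4 `CN(c1cccnc1)c1cnc(NCc2c(F)ccc3c2CCO3)n2cnnc12` carries methyl(pyridin-3-yl)amino in place of ((pyridin-3-yl)carbonyl)amino on an aromatic carbon.

The closest measured change is an at least 18-fold lower number from compound 2 to compound 3 (1.26 log units; beyond the scatter) and it runs the opposite way, with ((pyridin-3-yl)carbonyl)amino entering. When methyl(phenyl)amino enters, an at least 18-fold higher number from compound 1 to compound 2 (1.26 log units; beyond the scatter) is just as large. By contrast, a step that the two limits leave unreadable from compound 1 to compound 3 gives no size to use. For the measured compounds named here, compound 2 with 55 mL.min-1.g-1 is the nearest guide, but no measured step tests pyridin-3-yl in place of phenyl there, so a large rise is expected with an uncertain height. The estimated change is an at least 6.6-fold higher number from compound 3 to compound 4 (0.82 log units; beyond the scatter) and it is expected to lie beyond the scatter. Compound 4 is estimated at 20 mL.min-1.g-1 with an expected range from 6 mL.min-1.g-1 to 55 mL.min-1.g-1 (an estimate, not a measurement).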

Compound 4, intrinsic clearance in microsomes: 80 mL.min-1.g-1
The estimate for compound 4 lay 4.0-fold (0.60 log units) below the measured number, outside the stated range (above it).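

Putting methyl(pyridin-3-yl)amino in place of ((pyridin-3-yl)carbonyl)amino at this position gives an at least 26-fold higher number from compound 3 to compound 4 (1.42 log units; beyond the scatter) in this assay, and putting it in place of ((2-methoxyethyl)carbonyl)amino gives an at least 26-fold higher number from compound 1 to compound 4 (1.42 log units; beyond the scatter). For the compounds shown here, the change of ring, tested here for the first time, gives a 1.5-fold higher number from compound 2 to compound 4 (0.16 log units; within the scatter), so pyridin-3-yl and phenyl on this nitrogen cannot be told apart in this read-out. Among the four compounds, both groups with a carbonyl sit at the assay limit and both methyl-substituted amino groups give high numbers, with no compound going against this.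

Going by these compounds, the full height of the two large rises stays unknown, since compound 1 and compound 3 carry limits rather than numbers: the limit of < 3 mL.min-1.g-1 in this assay, at which 2 of the 4 values shown sit. On these data alone, whether losing the carbonyl or gaining the methyl matters more also stays open, and a plain (pyridin-3-yl)amino group, carrying neither, would separate the two.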